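The source may hold more compounds than are shown below. What is called first, only, known or untested is meant among the compounds shown, and "the series" means these compounds.

In an assay for positive allosteric modulation of metabotropic glutamate receptor 2 (Rattus norvegicus) (on this read-out lower numbers stand for an effect already at smaller amounts and higher numbers for an effect only at larger amounts of compound), the measured compounds are: compound 1 `Cc1ccc(C(=O)O)cc1OCCCCOc1ccc(C(=O)CC(C)(C)C)c(O)c1C` with 512 nM; compound 2 `Cc1c(OCCCCOc2ccc(C(=O)O)cc2F)ccc(C(=O)CC(C)(C)C)c1O` with 75 nM; compound 3 `COc1ccc(C(=O)O)cc1OC[C@H](C)COc1ccc(C(=O)CC(C)(C)C)c(O)c1C` with 63 nM.

Compound 3 carries the lowest number of the three, but its gap to compound 2 lies within the scatter, so those two cannot be ordered; only compound 1 stands clearly apart from it. Compound 4 `COc1ccccc1OC[C@H](C)COc1ccc(C(=O)CC(C)(C)C)c(O)c1C` differs from compound 3 by hydrogen in place of carboxy on an aromatic carbon. For the measured compounds named here, the one measured step, a 6.8-fold lower number from compound 1 to compound 2 (0.83 log units; beyond the scatter), exchanges one carboxy-bearing ring for another and keeps the carboxy throughout, so no measured step speaks to its removal. Without a guide in the data, the number is expected to rise, with wide uncertainty, by a step of a 6.3-fold higher number from compound 3 to compound 4 (0.80 log units; beyond the scatter). Compound 4 is therefore estimated at 400 nM, between 80 nM and 4000 nM.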

Compound 4, half-maximal effective concentration: "not active" (no number reported)
Compound 4: no number reported; there is nothing to compare the estimate with.
By their numbers in this assay, from the lowest: compounds 3 and 2 (each within the scatter of the next); then compound 1.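

For the compounds shown here, compound 4 is reported only as not active, with no number, so no step from compound 3 at 63 nM to compound 4 can be read. No measurement at hand accounts for this result. The compounds shown leave open how large the effect of exchanging carboxy for hydrogen is.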